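A Benzyl Group Returns to the Ring Amine

The compounds below may be only part of what the source reports. "The series", "measured", "known", "first", "only" and "open" are said of these compounds alone.

Measured so far in a functional assay on MCF7 cells (Homo sapiens) for antiproliferative activity, read by sulforhodamine B assay, with a stated time of 72 h; on this read-out higher numbers stand for weaker inhibition and lower numbers for stronger inhibition:
compound 1 `N#Cc1ccc(COc2ccc(-c3cc(CN4CCN(Cc5ccc(C(F)(F)F)cc5)CC4)no3)cc2)cc1` gives 100 nM;
compound 2 `COc1ccc(COc2ccc(-c3cc(CN4CCN(Cc5ccc(C(F)(F)F)cc5)CC4)no3)cc2)cc1` gives 1300 nM;
compound 3 `N#Cc1cccc(COc2ccc(-c3cc(CN4CCN(c5ccc(C(F)(F)F)cn5)CC4)no3)cc2)c1` gives 1400 nM.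

Compound 3 carries the highest number of the three; compound 2 sits within the scatter of it, while compound 1 lies well below, beyond the scatter. Compound 4 `N#Cc1cccc(COc2ccc(-c3cc(CN4CCN(Cc5ccccc5F)CC4)no3)cc2)c1` differs from compound 3 in one place: 2-fluorobenzyl in place of 5-(trifluoromethyl)pyridin-2-yl on an amine nitrogen in a ring. Among the measured compounds shown here, the only measured single-point step, a 13-fold higher number from compound 1 to compound 2 (1.11 log units; beyond the scatter), concerns a different position and bears on this change only loosely. Compounds 1 and 2 both carry a benzyl group on the ring amine, and compound 1 reaches the lowest number shown, so a move toward that pattern is expected to lower the number, with wide uncertainty. Compound 4 is therefore estimated at 400 nM, with a range from 100 nM to 1500 nM. The expected step is a 3.5-fold lower number from compound 3 to compound 4 (0.54 log units; beyond the scatter).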

Compound 4, half-maximal inhibitory concentration: 1400 nM
Beside the measured number, compound 4's estimate is 3.5-fold (0.54 log units) below it, and the stated range covers the measured number.
By their numbers in this assay, from the lowest: compound 1; then compounds 2, 3 and 4 (each within the scatter of the next).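

In this assay, putting 2-fluorobenzyl in place of 5-(trifluoromethyl)pyridin-2-yl on the ring amine gives no change at the digits printed from compound 3 to compound 4 (within the scatter), so a benzyl group at this nitrogen does not by itself lower the number. The exchange also drops the one hydrogen-bond acceptor counted on the leaving group and removes the ring nitrogen, yet the read-out does not separate the two groups. Nothing available explains this match.

On these data alone, it remains open whether an unsubstituted benzyl group or a benzyl group carrying a carboxylic acid would shift the number at this nitrogen.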